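From a Free Hydroxy Group to Its Acetate

A few compounds are considered here, and "the series" means these few. Any claim that something is new, unique, unknown or untested is made for them only; others in the source may bear on it.

Compound 2 `CCC[C@@H](O)C1=C(Br)/C(=C/I)OC1=O` was tested in a functional assay on Lu1 cells (Homo sapiens) for cytotoxicity (a higher number here means that more compound is needed for the effect, a lower number that less compound is needed), where compound 2 gives 1.3 ug/mL. Compound 1 `CCC[C@@H](OC(C)=O)C1=C(Br)/C(=C/Br)OC1=O` gives 1.7 ug/mL in this assay, a number within the scatter of compound 2, so the two stand together. Compound 3 `CCC[C@@H](OC(C)=O)C1=C(Br)/C(=C/I)OC1=O` has not yet been measured. It differs from compound 2 by acetyl in place of hydrogen on an oxygen on a saturated carbon, that is, hydroxy to acetoxy. Compound 1 also carries an acetyl group on an oxygen, and with 1.7 ug/mL it sits close to compound 2, so the step of a 1.2-fold higher number from compound 2 to compound 3 (0.06 log units; within the scatter) is expected to stay within the scatter. Compound 3 is expected to give about 1.5 ug/mL, between 0.7 ug/mL and 3.2 ug/mL.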

Compound 3, concentration for half-maximal effect: 1.5 ug/mL
The estimate for compound 3 equals the measured number at the digits printed; low and high end bracket the measured number.
By their numbers in this assay, from the lowest: compounds 2, 3 and 1 (each within the scatter of the next).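

In this assay, acetyl in place of hydrogen on this oxygen gives a 1.2-fold higher number from compound 2 to compound 3 (0.06 log units; within the scatter), so with the iodo group held fixed, the hydroxy and acetoxy forms stand together. With the acetoxy group held fixed, iodo in place of bromo gives a 1.1-fold lower number from compound 1 to compound 3 (0.05 log units; within the scatter), so that change also stays within the scatter. Nothing available explains why either change does so little.

Going by these compounds, whether a longer acyl chain on this oxygen would also stay within the scatter remains open. So does the effect of an amine at this place.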